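The source may hold more compounds than are shown below. What is called first, only, known or untested is meant among the compounds shown, and "the series" means these compounds.

Measured so far in a functional assay; on this read-out lower numbers stand for stronger inhibition and higher numbers for weaker inhibition:

compound 1 `COc1ccc(C2CC(=O)c3ccc(OCC=C(C)C)cc3O2)cc1` gives 10200 nM
compound 2 `CC(C)=CCOc1ccc2c(c1)OC(c1ccc(C)cc1C)CC2=O` gives 8260 nM
compound 3 `COc1ccc(C2CC(=O)c3c(O)cc(OCC=C(C)C)cc3O2)cc1` gives 5080 nM

Compound 2 differs from compound 1 by 2,4-dimethylphenyl in place of 4-methoxyphenyl on a saturated ring carbon; the step in this assay is a 1.2-fold lower number from compound 1 to compound 2 (0.09 log units; within the scatter). Compound 3 differs from compound 1 in the core by hydroxy in place of hydrogen on an aromatic carbon, and the step is a 2.0-fold lower number from compound 1 to compound 3 (0.30 log units; within the scatter). Compound 3 has the lowest of the three numbers, but its gaps to compound 1 and compound 2 are both within the scatter, so no order among the three is claimed.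

Compound 4 `CC(C)=CCOc1cc(O)c2c(c1)OC(c1ccc(C)cc1C)CC2=O` is not yet measured. It differs from compound 3 by 2,4-dimethylphenyl in place of 4-methoxyphenyl on a saturated ring carbon, the same change as from compound 1 to compound 2: the place is described in identical words, so it is the same change on the core of compound 3. Among the compounds with values here, with only one earlier instance of this change, the expectation rests on that single step, which was within the scatter. For compound 4 the expected step is therefore a 1.2-fold lower number from compound 3 to compound 4 (0.07 log units; within the scatter), because a 1.2-fold lower number from compound 1 to compound 2 (0.09 log units; within the scatter) was small. Compound 4 is accordingly estimated at 4300 nM, with a range from 2000 nM to 9500 nM.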

Compound 4, half-maximal inhibitory concentration: 6380 nM
For compound 4 the middle estimate is 1.5-fold (0.17 log units) below the measured one; measured number inside the range.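

In this assay, the step for 2,4-dimethylphenyl in place of 4-methoxyphenyl on the core of compound 3 is a 1.3-fold higher number from compound 3 to compound 4 (0.10 log units; within the scatter), and it does not differ from the earlier instance of this change: the same change on two cores in this assay, a 1.2-fold lower number (0.09 log units; within the scatter) from compound 1 to compound 2 and a 1.3-fold higher number (0.10 log units; within the scatter) from compound 3 to compound 4, 1.6-fold (0.19 log units) apart, within the scatter of two such steps. The step for hydroxy in place of hydrogen on an aromatic carbon, now read on the core of compound 2, is a 1.3-fold lower number from compound 2 to compound 4 (0.11 log units; within the scatter), and it also matches its earlier instance: the same change on two cores in this assay, a 2.0-fold lower number (0.30 log units; within the scatter) from compound 1 to compound 3 and a 1.3-fold lower number (0.11 log units; within the scatter) from compound 2 to compound 4, 1.6-fold (0.19 log units) apart, within the scatter of two such steps. Both changes therefore carry between these two cores without a detectable difference, but all four steps lie within the scatter, so this is agreement between steps too small to resolve, and it does not show that either change alters inhibition or that a sizeable step would carry over in the same way.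

From the compounds shown here alone, it remains open whether an amine or a carboxylic acid in place of 4-methoxyphenyl on the saturated ring carbon would give a step beyond the scatter. Going by these compounds, it also remains open whether either change would behave in the same way on a core outside these four compounds.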